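A few compounds are considered here, and "the series" means these few. Any claim that something is new, unique, unknown or untested is made for them only; others in the source may bear on it.

Measured so far:
compound 1, `CCCCCc1cc2ccccc2nc1-c1cn(CCC(F)(F)C(F)(F)C(F)(F)C(F)(F)C(F)(F)C(F)(F)C(F)(F)C(F)(F)F)nn1`: in a functional assay on U-937 cells (Homo sapiens) for cytotoxicity, read by MTT assay, with a stated time of 24 h (on this read-out higher numbers stand for weaker inhibition and lower numbers for stronger inhibition), compound 1 gives > 100 ug/mL, which is a limit of the assay rather than a number.
compound 2, `Cc1cc2ccccc2nc1-c1cn(-c2ccc(F)cc2)nn1`: in this assay compound 2 gives 65.6 ug/mL.

Compound 1 stands at the limit of > 100 ug/mL in this assay, at which 1 of the 2 values shown sits; for it only a limit is known, no exact number. Compound 2 gives a number, and the two results, one a limit and one a value, are the whole of what has been measured here. Compound 3, `CCc1cc2ccccc2nc1-c1cn(CCC(F)(F)C(F)(F)C(F)(F)C(F)(F)C(F)(F)C(F)(F)C(F)(F)C(F)(F)F)nn1`, is the next compound to be measured. It keeps the core and the long fluorinated chain of compound 1 and differs from it by hydrogen in place of propyl on a saturated chain carbon, two bonds along the chain from an aromatic carbon. For the measured compounds named here, no pair of measured compounds shows this kind of change, so its effect has no precedent in these data. The expected step from compound 1 to compound 3 in this assay is a step that the limit leaves unreadable from compound 1 to compound 3, that is, nothing beyond the usual scatter, so compound 3 is expected to sit at or near the same limit as compound 1. Compound 3 is therefore estimated at 120 ug/mL, with a range from 50 ug/mL to 300 ug/mL.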

Compound 3, half-maximal inhibitory concentration: 55.9 ug/mL
The estimate for compound 3 lay 2.1-fold (0.33 log units) above the measured number, within the range that was stated.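

With the long fluorinated chain kept in place, replacing propyl with hydrogen on the saturated chain carbon, which turns the pentyl chain into an ethyl chain, brings a readable number into this assay: compound 3 gives 55.9 ug/mL, so this chain does not by itself keep a compound from giving a readable number. The change amounts to an at least 1.7-fold lower number from compound 1 to compound 3 (0.25 log units; that floor lies within the scatter), which means that only a smallest possible size is known, and since that floor lies within the scatter, the data do not establish a step beyond the usual variation between repeats, although the true step could be larger. The size stays open because compound 1 carries a limit of the assay and not a number: the limit of > 100 ug/mL in this assay, at which 1 of the 3 values shown sits.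

A butyl or hexyl chain in this place would help show whether the number follows chain length or whether the pentyl chain stands apart from the ethyl chain. The compounds shown also leave open what an amine or a carboxylic acid on this chain carbon would do, and whether the same change would count for as much with a different group in place of the long fluorinated chain.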